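The compounds below may be only part of what the source reports. "The series", "measured", "known", "first", "only" and "open" are said of these compounds alone.

Compound 1 `CCS(=O)(=O)Nc1cccc(-c2c[nH]cn2)c1` and compound 2 `CCS(=O)(=O)Nc1cccc(Sc2c[nH]cn2)c1` share one core and differ only at one aromatic carbon. In an assay on isolated protein for binding affinity to Alpha-1D adrenergic receptor (Rattus norvegicus), read by radioligand binding (a lower number here means a stronger inhibitor, a higher number a weaker inhibitor), compound 1 gives < 10000 nM, which is a limit of the assay and not a number. In this assay compound 2 gives < 10000 nM, likewise a limit. The step that the two limits leave unreadable from compound 1 to compound 2 stays unreadable, since both entries sit at the limit of < 10000 nM in this assay, at which 2 of the 2 values shown sit. Compound 3 `CCS(=O)(=O)Nc1cccc(C2CCNC2)c1` carries pyrrolidin-3-yl in place of (1H-imidazol-4-yl)sulfanyl on an aromatic carbon. Going by the values given here, no measured step bears on this change, and compound 2 stands only at a limit. The step that the limit leaves unreadable from compound 2 to compound 3 is therefore an estimate without a measured anchor. Compound 3 is expected near 800 nM, within 100 nM to 6000 nM in this assay.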

Compound 3, inhibition constant: 1000 nM
Compound 3: middle estimate off by 1.3-fold (0.10 log units), on the low side; measured number inside the range.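

No step to compound 3 can be read in this assay from compound 1 or compound 2, since both stand at a limit: the limit of < 10000 nM in this assay, at which 2 of the 3 values shown sit.

The compounds shown leave open how much pyrrolidin-3-yl changes the value relative to 1H-imidazol-4-yl or (1H-imidazol-4-yl)sulfanyl.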